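Two Level Compounds and One Still Unmeasured

A few compounds are considered here, and "the series" means these few. Any claim that something is new, unique, unknown or untested is made for them only; others in the source may bear on it.

In a functional assay on HepG2 cells (Homo sapiens) for antiproliferative activity, read by MTT assay, with a stated time of 48 h (a higher number here means a weaker inhibitor, a lower number a stronger inhibitor), compound 1 (`O=[N+]([O-])c1cc(C(F)(F)F)cc([N+](=O)[O-])c1Oc1ccc(Cl)cc1/C=N\OCc1ccc(Cl)cc1Cl`) gives 1280 nM and compound 2 (`O=[N+]([O-])c1cc(C(F)(F)F)cc([N+](=O)[O-])c1Oc1ccc(Br)cc1/C=N/OCc1ccccc1Cl`) gives 1240 nM so compound 2 stands level with compound 1, within the scatter. The change leading to compound 3 (`O=[N+]([O-])c1cc(C(F)(F)F)cc([N+](=O)[O-])c1Oc1ccc(Br)cc1/C=N\OCc1ccc(Cl)cc1Cl`) is a group of 12 heavy atoms (8 carbon, 1 nitrogen, 1 oxygen, 2 chlorine; one six-membered aromatic ring of carbon only) in place of a group of 11 heavy atoms (8 carbon, 1 nitrogen, 1 oxygen, 1 chlorine; one six-membered aromatic ring of carbon only), on an aromatic carbon on an aromatic carbon, ortho to a large group. For the measured compounds named here, no measured step shows this change, so in this assay no shift beyond the scatter is expected. The estimated 1.0-fold lower number from compound 2 to compound 3 (0.01 log units; within the scatter) is expected to stay within that scatter. Compound 3 is expected near 1200 nM (estimated range 600 nM to 2400 nM).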

Compound 3, half-maximal inhibitory concentration: 1070 nM
Compound 3: middle estimate off by 1.1-fold (0.05 log units), on the high side; the range from low to high includes it.
By their numbers in this assay, from the lowest: compounds 3, 2 and 1 (each within the scatter of the next).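

In this assay the group of 12 heavy atoms, with its second chlorine, in place of the group of 11 heavy atoms gives a 1.2-fold lower number from compound 2 to compound 3 (0.06 log units; within the scatter) and so shows no shift beyond the scatter for this change at this position. Bromo in place of chloro on an aromatic carbon gives a 1.2-fold lower number from compound 1 to compound 3 (0.08 log units; within the scatter) and is likewise no shift beyond the scatter. Nothing at hand bears on either step. The compounds shown leave open whether an amine or a carboxylic acid in place of the chloro or bromo would move the number beyond the scatter.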